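Fluorophenyl ring position on the triazole of compound 1

This account rests on a few compounds, and the source may have more. Where it says the series, first, only, none or still open, it means among the compounds named here.

Compound 1 `COc1nc2ccc(Br)cc2cc1C(c1ccccc1)n1cc(-c2ccccc2F)nn1` carries a 2-fluorophenyl on the five-membered ring of the shared core. In an ADME assay on PANC-1 cells (Homo sapiens) for cytotoxicity, read by sulforhodamine B assay, with a stated time of 48 h, tested at 10 uM (a lower number here means less inhibition, a higher number more inhibition at the concentration tested (going by the name of the read-out)), compound 1 gives 14.7%. Among the measured compounds shown here, its only measured neighbour is compound 2 `CCCCCCCc1cn(C(c2ccccc2)c2cc3cc(Br)ccc3nc2OC)nn1`, in which the 2-fluorophenyl of compound 1 is replaced by heptyl; in this assay compound 2 gives 16.6%. The step of a number 1.9 percentage points higher from compound 1 to compound 2 (within the scatter) lies within the scatter, so compound 1 and compound 2 are not separated by the numbers.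

Compound 3 `COc1nc2ccc(Br)cc2cc1C(c1ccccc1)n1cc(-c2ccc(F)cc2)nn1` differs from compound 1 by 4-fluorophenyl in place of 2-fluorophenyl on an aromatic carbon. For the measured compounds named here, no measured pair shows this exact change. Going by the values given here, the one step at the same position, from compound 1 to compound 2, was within the scatter despite a much larger change of group, which gives no reason to expect a shift beyond the scatter from a move of the fluorine within the same ring. The step of a number 0.8 percentage points higher from compound 1 to compound 3 (within the scatter) is therefore expected to fall within the scatter, with no clear direction. In this assay compound 3 is estimated at 15.5%, with a range from 5% to 28%.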

Compound 3, a percentage reported as inhibition, at one concentration (the size of the read-out at that concentration, not a potency): 14.9%
For compound 3 the middle estimate is 0.6 percentage points above the measured one, and the stated range covers the measured number.
By their numbers in this assay, from the lowest: compounds 1, 3 and 2 (each within the scatter of the next).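

Moving the fluorine within the ring, on an aromatic carbon of the five-membered aromatic ring with 3 nitrogen, gives in this assay a number 0.2 percentage points higher from compound 1 to compound 3 (within the scatter) and so does not separate 2-fluorophenyl from 4-fluorophenyl at this position. Exchanging heptyl for 4-fluorophenyl at the same carbon gives a number 1.7 percentage points lower from compound 2 to compound 3 (within the scatter) and thus, like the earlier step from compound 1 to compound 2, does not separate a fluorophenyl group from the heptyl chain, leaving all three listed compounds unresolved by their numbers. No measurement shown offers an explanation for this reading.

Going by these compounds, whether a group of another kind at this carbon, such as an amine, a carboxylic acid or a chain longer than heptyl, would give a step beyond the scatter remains open. Also open, on these data alone, is whether the fluorine on the phenyl ring matters at all, as an unsubstituted phenyl or a 3-fluorophenyl at this position would be needed to place the two fluorophenyl compounds in a wider comparison.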